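This account rests on a few compounds, and the source may have more. Where it says the series, first, only, none or still open, it means among the compounds named here.

Working notes on the series. Compound 2, `Cc1cccc(C)c1-c1cccc(COc2ccc(C(C)CC(=O)O)cn2)c1`, gives 320 nM in a functional assay on CHO cells for agonist activity at Free fatty acid receptor 1 (Rattus norvegicus), read by calcium flux; on this read-out higher numbers stand for an effect only at larger amounts of compound and lower numbers for an effect already at smaller amounts. For the measured compounds named here, on the two numbers measured so far it carries the higher one, although the gap to compound 1 is small: compound 1, `Cc1cccc(C)c1-c1cccc(COc2ccc(CC(F)C(=O)O)cn2)c1`, gives 250 nM, and the step of a 1.3-fold higher number from compound 1 to compound 2 (0.11 log units; within the scatter) stays within the scatter.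

Compound 3, `CCOC(CC(=O)O)c1ccc(OCc2cccc(-c3c(C)cccc3C)c2)nc1`, has not been measured. It differs from compound 2 in one place: ethoxy in place of methyl on a saturated chain carbon bound to an aromatic carbon and a saturated chain carbon. Going by the values given here, no measured step alters this position; the only measured step, the one from compound 1 to compound 2, changes the carboxy-bearing chain itself and was within the scatter. The data therefore give no direction for this change, and no step beyond the scatter is expected in this assay for compound 3, with a wide range to allow for the untested position. The expected step for compound 3 is a 1.3-fold higher number from compound 2 to compound 3 (0.10 log units; within the scatter). The estimate for compound 3 in this assay is 400 nM, between 130 nM and 1200 nM.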

Compound 3, half-maximal effective concentration: 130 nM
Compound 3: the middle estimate sits 3.1-fold (0.49 log units) above what was measured; the measured number falls inside the stated range.
By their numbers in this assay, from the lowest: compounds 3, 1 and 2 (each within the scatter of the next, the first and the last beyond it).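

In this assay, for the compounds shown here, the saturated chain carbon bound to an aromatic carbon and a saturated chain carbon proves responsive to substitution: a 2.5-fold lower number from compound 2 to compound 3 (0.39 log units; beyond the scatter) is the first step beyond the scatter, with ethoxy, of 3 heavy atoms and with 1 hydrogen-bond acceptor, entering in place of methyl, of 1 heavy atom. The 2-carboxy-1-ethoxyethyl chain and the 2-carboxy-2-fluoroethyl chain, by contrast, are not separated on this read-out, with a 1.9-fold lower number from compound 1 to compound 3 (0.28 log units; within the scatter) as the step between them. No measured evidence bears on what lies behind the ethoxy step, which stands as an observation only.

The compounds shown leave open whether the lower number follows the oxygen of the ethoxy group or simply the longer chain, a question that a propyl group, with carbon alone, and a methoxy group, with the oxygen on a shorter chain, at this same carbon would help to settle. Also open, on these data alone, is whether a hydroxy group or an amine would be accepted at this carbon, and whether the ethoxy step would hold with a fluorine also on the carboxy-bearing chain.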